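A phenol returns on the hydrazone arm

The source may hold more compounds than are shown below. What is called first, only, known or untested is meant among the compounds shown, and "the series" means these compounds.

Compound 2 `CN(C)CCn1cnnc1-c1cc(Oc2ccc(NC(=O)N/N=C/c3cccc(Br)c3)cc2F)ccn1` gives the lowest of the two numbers in a functional assay on NCI-H460 cells (Homo sapiens) for cytotoxicity, read by MTT assay, with a stated time of 72 h (on this read-out higher numbers stand for weaker inhibition and lower numbers for stronger inhibition), namely 520 nM. Compound 1 `CN(C)CCn1cnnc1-c1cc(Oc2ccc(NC(=O)N/N=C/c3ccc(O)c(O)c3)cc2F)ccn1` gives 1930 nM, and the step of a 3.7-fold lower number from compound 1 to compound 2 (0.57 log units; beyond the scatter) came with 3-bromophenyl in place of 3,4-dihydroxyphenyl on a carbon with a double bond to nitrogen. Compound 3 `Cc1cc(/C=N/NC(=O)Nc2ccc(Oc3ccnc(-c4nncn4CCN(C)C)c3)c(F)c2)cc(C)c1O` differs from compound 2 by 4-hydroxy-3,5-dimethylphenyl in place of 3-bromophenyl on a carbon with a double bond to nitrogen. Since a hydroxyl re-enters, a modest rise in the number is expected, though smaller than the step seen, because compound 1 1930 nM carried two hydroxyls. Compound 3 is therefore estimated at 1100 nM, between 500 nM and 2500 nM, a step of a 2.1-fold higher number from compound 2 to compound 3 (0.33 log units; beyond the scatter).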

Compound 3, half-maximal inhibitory concentration: 2010 nM
The estimate for compound 3 lay 1.8-fold (0.26 log units) below the measured number; the range from low to high includes it.
By their numbers in this assay, from the lowest: compound 2; then compounds 1 and 3 (each within the scatter of the next).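

In this assay, a hydroxyl-bearing ring again gives the higher number: a 3.9-fold higher number from compound 2 to compound 3 (0.59 log units; beyond the scatter). Both phenol-type groups stand level, with a 1.0-fold higher number from compound 1 to compound 3 (0.02 log units; within the scatter), so 4-hydroxy-3,5-dimethylphenyl gives no advantage over 3,4-dihydroxyphenyl at this position, even with fewer hydroxyl groups, though the two groups also differ by their methyl groups. No available evidence accounts for the gap between these groups and 3-bromophenyl. Still open, as far as these compounds go, is whether bromine itself matters, or whether 3-chlorophenyl would match it. From the compounds shown here alone, the effect of an amine or a carboxylic acid on this ring also remains open.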